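A few compounds are considered here, and "the series" means these few. Any claim that something is new, unique, unknown or untested is made for them only; others in the source may bear on it.

Compound 3, `COc1cccc(C(=O)Oc2cc3c(C)ccc(C(C)C)c3cc2C)c1`, gives the highest of the three numbers in a functional assay on SK-LU-1 cells (Homo sapiens) for antiproliferative activity, read by sulforhodamine B assay, with a stated time of 48 h, tested at 50 uM (a lower number here means less inhibition, a higher number more inhibition at the concentration tested (going by the name of the read-out)), but its margin over compound 2 is within the usual scatter and only its margin over compound 1 is beyond it. Compound 1, `Cc1cc2c(C(C)C)ccc(C)c2cc1OC(=O)c1cccc(C(F)(F)F)c1`, gives 17.3%; compound 2, `Cc1cc2c(C(C)C)ccc(C)c2cc1OC(=O)c1ccc(C(F)(F)F)cc1`, gives 28.7%; compound 3 gives 30.6%. Within the data shown here, the one measured step, a number 13.3 percentage points higher from compound 1 to compound 3 (beyond the scatter), concerns methoxy in place of trifluoromethyl on an aromatic carbon. Compound 4, `Cc1cc2c(C(C)C)ccc(C)c2cc1OC(=O)c1ccc([N+](=O)[O-])cc1`, differs from compound 3 by 4-nitrophenyl in place of 3-methoxyphenyl on a carbonyl carbon. Among the measured compounds shown here, no measured step involves a nitro group, so the measured step bears on the change only loosely, as a sign that swapping the substituent on this ring can move the read-out by a modest amount in either direction. The two trifluoromethyl compounds show that the position of a group on the ring also matters, with compound 1 and compound 2 apart by more than the scatter. Compound 4 is therefore expected to sit near compound 3, with a number 2.6 percentage points lower from compound 3 to compound 4 (within the scatter) expected, giving an estimate of 28% within 14% to 44%.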

Compound 4, a percentage reported as inhibition, at one concentration (the size of the read-out at that concentration, not a potency): 100%
Beside the measured number, compound 4's estimate is 72 percentage points below it; measured number above the stated range.
By their numbers in this assay, from the lowest: compound 1; then compounds 2 and 3 (each within the scatter of the next); then compound 4.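

In this assay, nitro in place of trifluoromethyl on an aromatic carbon gives a number 71.3 percentage points higher from compound 2 to compound 4 (beyond the scatter), showing that a single exchange of a ring substituent, with the rest of the molecule unchanged, can move the read-out far more than the earlier a number 13.3 percentage points higher from compound 1 to compound 3 (beyond the scatter). The exchange of 4-nitrophenyl for 3-methoxyphenyl on a carbonyl carbon gives a number 69.4 percentage points higher from compound 3 to compound 4 (beyond the scatter), but it alters both the group and where the group sits on the ring, so this step alone cannot separate those two changes. Nothing available explains why compound 4 stands so far apart from the others.

The compounds shown leave open whether this large gain is peculiar to nitro or would also appear with a nitrile or an amine on the same ring. They also leave open whether nitro would give a similar number as 3-nitrophenyl, and a reading at one concentration gives no potency for compound 4.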